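Methyl to Trifluoromethyl in Two Weakly Active Series

The source may report more compounds than this note shows. Statements on the series, on what has been measured and on what is new or still open speak of the compounds shown alone.

Of the compounds shown here, three have been tested in a functional assay on A549 cells (Homo sapiens) for antiproliferative activity, read by sulforhodamine B assay, with a stated time of 72 h; on this read-out lower numbers stand for stronger inhibition of growth and higher numbers for weaker inhibition of growth. Compound 1 `Cc1cc(=O)oc2cc(SCc3cccc(C(F)(F)F)c3)ccc12` reaches only the assay's upper limit there, > 28500 nM, so no number is reported for it. Compound 2 `Cc1cccc(CSc2ccc3c(C)cc(=O)oc3c2)c1` likewise gives only a limit, > 33700 nM. Within the data shown here, compound 3 `CCc1cc(=O)c2ccc(OCc3cccc(C)c3)c(C)c2o1`, built on a different core, is the one compound with a measured number: in this assay compound 3 gives 24900 nM, which is weak growth inhibition.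

Compound 1 and compound 2 differ by trifluoromethyl in place of methyl on an aromatic carbon. Because both sit at limits, the step that the two limits leave unreadable from compound 2 to compound 1 cannot be read in either direction; this rests on the limit of > 28500 nM in this assay, at which 1 of the 3 values shown sits, and (the limit of > 33700 nM in this assay, at which 1 of the 3 values shown sits). The difference between the core of compound 2 and the core of compound 3 is not broken down here.

Compound 4 `CCc1cc(=O)c2ccc(OCc3cccc(C(F)(F)F)c3)c(C)c2o1` has not yet been measured. It differs from compound 3 by trifluoromethyl in place of methyl on an aromatic carbon, the same change that separates compound 2 from compound 1, with the same surroundings at the place of change. Nothing in the measured pair shows how large such a step can be, and compound 3 itself lies close to where the assay stops reporting numbers. The step from compound 3 to compound 4 is therefore expected to be small, a 1.0-fold higher number from compound 3 to compound 4 (0.00 log units; within the scatter), with a real chance that only a limit is returned. Compound 4 is estimated at 25000 nM in this assay, most likely between 9000 nM and 60000 nM.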

Compound 4, concentration for 50% growth inhibition: > 27600 nM
Compound 4: only a limit was reported; the forecaster's own chance of this, stated with the estimate: 50%; middle value at least 1.1-fold (0.04 log units) from the limit.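

In this assay compound 4 gives only a limit, > 27600 nM, and not a number. Set against the measured value of compound 3, trifluoromethyl in place of methyl on an aromatic carbon gives an at least 1.1-fold higher number from compound 3 to compound 4 (0.04 log units; that floor lies within the scatter), so on this core the change brings no sign of stronger growth inhibition, though the true size of the step remains unknown and could be larger than this floor. The same change on the other core, from compound 2 to compound 1, has limits at both ends, so that step cannot be read and nothing shows whether the change has an effect of similar size on the two cores: the limit of > 28500 nM in this assay, at which 1 of the 4 values shown sits, and the limit of > 33700 nM in this assay, at which 1 of the 4 values shown sits.

The compounds shown leave open whether another group at this place on the aromatic ring, such as an amine or a carboxylic acid, would give growth inhibition strong enough to be reported as a number on either core. They also leave open how far past its limit the true value of compound 4 lies, and therefore whether trifluoromethyl weakens growth inhibition on this core at all.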